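This account rests on a few compounds, and the source may have more. Where it says the series, first, only, none or still open, it means among the compounds named here.

Series notes, cytotoxicity. Compound 1 `CC(C)[C@H](NC(=O)[C@]1(Cc2ccccc2)CCN1C(=O)OCc1ccccc1)C(N)=O` and compound 2 `CC(C)CNC(=O)[C@H](C)NC(=O)[C@]1(Cc2ccccc2)CCN1C(=O)OCc1ccccc1` share the same core. In an ADME assay on HELF cells (Homo sapiens) for cytotoxicity, with a stated time of 3 days (on this read-out higher numbers stand for lower toxicity in this test and lower numbers for higher toxicity in this test), compound 1 gives 100000 nM. For compound 2 the result in this assay is a limit of the assay, > 100000 nM. The step of a number no lower from compound 1 to compound 2 (the limit leaves the size open) therefore cannot be sized; it is bounded only by the limit of > 100000 nM in this assay, at which 1 of the 2 values shown sits. Compound 2 thus stands at the limit of what this assay reports, with no number of its own.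

Compound 3 `C[C@H](NC(=O)[C@]1(Cc2ccccc2)CCN1C(=O)OCc1ccccc1)C(=O)NCc1ccccc1` differs from compound 2 by phenyl in place of isopropyl on a saturated chain carbon bound to an amide-type nitrogen; cut one bond further out this reads as isobutylcarbamoyl to benzylcarbamoyl. Among the measured compounds shown here, the only measured step, a number no lower from compound 1 to compound 2 (the limit leaves the size open), is a change of the same part of the molecule, with its size left open; it gives no sign that changes at this position move the read-out in this assay out of the scatter. The step of a number no higher from compound 2 to compound 3 (the limit leaves the size open) is therefore expected to be none beyond the scatter. Compound 3 is estimated at 100000 nM, within 50000 nM to 200000 nM, and is expected most likely to be reported again as a limit in this assay.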

Compound 3, half-maximal cytotoxic concentration: 42000 nM
For compound 3 the middle estimate is 2.4-fold (0.38 log units) above the measured one; the whole stated range lies above it.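

In this assay the change from isobutylcarbamoyl to benzylcarbamoyl gives an at least 2.3-fold lower number from compound 2 to compound 3 (0.37 log units; beyond the scatter), the first sign that this position can move the read-out beyond the scatter, in the direction of higher toxicity in this test. The replacement of 1-carbamoyl-2-methylpropyl by 1-(benzylcarbamoyl)ethyl gives a 2.4-fold lower number from compound 1 to compound 3 (0.38 log units; beyond the scatter), a modest step that can be sized at both ends, so the shift is also seen against a compound with a number of its own. The step from the isobutyl amide remains a lower bound on the size of the change, because compound 2 has only a limit of the assay and no number: the limit of > 100000 nM in this assay, at which 1 of the 3 values shown sits.

With a single benzyl example, the series does not show whether the shift follows the aromatic ring itself, and a cyclohexylmethyl amide or a longer chain such as phenethyl would test that. Also open, from the compounds shown here alone, is whether an amine or a carboxylic acid on this end of the molecule would keep the read-out near that of compound 3 or return it towards that of compound 1.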